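Cytotoxicity in mouse fibroblasts: an aniline swapped for difluorophenyl

This account rests on a few compounds, and the source may have more. Where it says the series, first, only, none or still open, it means among the compounds named here.

Compound 1, `Nc1cc(-c2ccccc2)ccc1Cn1cncc1CNc1ccc(Cl)c(-c2ccccc2)c1`: > 1000 nM
Compound 2, `COC(=O)c1ccc(NCc2cncn2Cc2ccc(N)cc2)cc1-c1ccccc1`: > 10000 nM
Compound 3, `c1ccc(-c2ccc(Cn3cncc3CNc3ccccc3-c3ccccc3)cc2)cc1`: > 10000 nM

All three compounds were tested in a toxicity assay on NIH3T3 cells (Mus musculus) for cytotoxicity, read by resazurin assay; on this read-out higher numbers stand for an effect only at larger amounts of compound and lower numbers for an effect already at smaller amounts. For compound 1 the value > 1000 nM is a limit of the assay rather than a number. For compound 2 the value > 10000 nM is likewise only a limit. Compound 3 also sits at a limit, > 10000 nM. So far no compound gives a measurable number at all, as the limit of > 1000 nM in this assay, at which 1 of the 3 values shown sits, and the limit of > 10000 nM in this assay, at which 2 of the 3 values shown sit, show.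

Compound 4, `COC(=O)c1ccc(NCc2cncn2Cc2ccc(F)cc2F)cc1-c1ccccc1`, differs from compound 2 in one place: 2,4-difluorophenyl in place of 4-aminophenyl on a saturated chain carbon bound to an aromatic nitrogen.

No step beyond the usual scatter is expected from compound 2 to compound 4, a step that the limit leaves unreadable from compound 2 to compound 4, because compound 2 stands at the limit of > 10000 nM in this assay, at which 2 of the 3 values shown sit. Compound 4 is therefore estimated at 15000 nM, within 5000 nM to 50000 nM, most probably reported again as a limit.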

Compound 4, half-maximal effective concentration: > 1000 nM
Compound 4 gave a limit, no number (the forecaster's own chance of this, stated with the estimate: 80%); the middle value does not contradict the limit.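

Among the compounds shown here, compound 2 and compound 4 both give only limits in this assay, and no step between them can be read. The compounds shown leave open at what concentration any of them would affect these cells.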